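Two compounds at the assay limit, and a third

A few compounds are considered here, and "the series" means these few. Any claim that something is new, unique, unknown or untested is made for them only; others in the source may bear on it.

In an ADME assay on HepG2 cells (Homo sapiens) for cytotoxicity, with a stated time of 72 h (a lower number here means that less compound is needed, a higher number that more compound is needed for the effect), compound 1 `Cc1cc(NC(=O)Nc2ccc(C)c(Cl)c2)c2ccccc2n1` gives > 25000 nM, a limit of the assay and not a number. Compound 2 `Cc1cc(NC(=O)Nc2ccccc2N)c2ccccc2n1` gives > 25000 nM, also a limit. Compound 2 therefore has no number of its own, only its place at the limit of > 25000 nM in this assay, at which 2 of the 2 values shown sit. Compound 3 `Cc1ccc(NC(=O)Nc2cc(C)nc3ccccc23)cc1` carries 4-methylphenyl in place of 2-aminophenyl on an amide-type nitrogen. No measured step sizes this change, so in this assay the expected step, a step that the limit leaves unreadable from compound 2 to compound 3, lies within the scatter. Compound 3 is estimated at 30000 nM, with an expected range of 15000 nM to 60000 nM.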

Compound 3, half-maximal effective concentration: > 25000 nM
Compound 3 ended at the assay's limit (the forecaster's own chance of this, stated with the estimate: 85%); the middle value lies beyond the limit too.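

No step can be read among compound 1, compound 2 and compound 3 in this assay, since all three stand at a limit of the assay: the limit of > 25000 nM in this assay, at which 3 of the 3 values shown sit.

The compounds shown leave open how much of each would be needed for the effect, and whether either change shifts that amount at all.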